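This account rests on a few compounds, and the source may have more. Where it says the series, first, only, none or still open, it means among the compounds named here.

Of the compounds shown here, three have been measured in a functional assay on CHO cells for agonist activity at Alpha-1A adrenergic receptor (Homo sapiens), read by FLIPR and calcium flux (on this read-out higher numbers stand for larger maximal responses and lower numbers for smaller maximal responses), and compound 1, with the structure `Cn1ccc(-c2cccc3c2CCC3c2ncc[nH]2)n1`, gives the smallest response of the three at 19%. Its nearest neighbour on this read-out is compound 2, with the structure `Cc1c(OCC2=NCCN2)ccc(Cl)c1NS(C)(=O)=O`, which in this assay gives 60%, a number that stands beyond the scatter above compound 1. Furthest from compound 1 is compound 3, with the structure `CCS(=O)(=O)Nc1cccc(Cc2c[nH]cn2)c1`, which in this assay gives 96%, again beyond the scatter above compound 1. Within the data shown here, compounds 2 and 3 share neither the core of compound 1 nor any single-point relation to it, so no step between measured compounds can be drawn here.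

The unmeasured compound 4, with the structure `c1cncc(-c2cccc3c2CCC3c2ncc[nH]2)c1`, keeps the core of compound 1 and differs in one place: pyridin-3-yl in place of 1-methyl-1H-pyrazol-3-yl on an aromatic carbon. Both groups carry the same count of heavy atoms, and the change removes one nitrogen and one hydrogen-bond acceptor while moving from a five-membered to a six-membered aromatic ring. Among the measured compounds shown here, with no comparable step among the measured compounds, the expected step from compound 1 to compound 4 in this assay is small and uncertain in direction, a number 11 percentage points higher from compound 1 to compound 4 (beyond the scatter), perhaps a modest rise but possibly none beyond the scatter. The maximal response of compound 4 in this assay is therefore estimated at 30%, within a range from 10% to 60%.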

Compound 4, largest response reached (Emax), in percent of the reference or control that the assay uses: 36%
Beside the measured number, compound 4's estimate is 6 percentage points below it; the range from low to high includes it.
By their numbers in this assay, from the lowest: compound 1; then compound 4; then compound 2; then compound 3.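

Among these compounds, the exchange of 1-methyl-1H-pyrazol-3-yl for pyridin-3-yl on an aromatic carbon of the shared core gives, in this assay, a number 17 percentage points higher from compound 1 to compound 4 (beyond the scatter), the first step that can be read on this core. It shows that the maximal response depends on which aromatic ring sits at this place, even when the heavy-atom count stays at 6, no hydrogen-bond donor enters and neither group carries a net charge. No measurement here gives a cause for this difference.

Among the compounds shown here, the single pair leaves open whether the step goes with the change from a five-membered to a six-membered aromatic ring, with the change from 2 hetero atoms to 1, or with the loss of the methyl group, because all of these changes occur together in this one exchange. Also open, on these data alone, are how the response would stand with a plain phenyl ring, a pyridin-4-yl ring, an aminomethyl group or a carboxylic acid on the same aromatic carbon, and whether the same exchange would give a similar step on another core.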